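The source may report more compounds than this note shows. Statements on the series, on what has been measured and on what is new or still open speak of the compounds shown alone.

Working notes on the series.

Of the compounds shown here, three of the shared core have been measured. Compound 1 `CN(C1CCN(CCCc2c[nH]c3ccc(-n4cnnc4)cc23)CC1)S(=O)(=O)c1ccccc1` gives 1.5 nM in an assay on CHO cells for displacement of a labelled ligand from 5-hydroxytryptamine receptor 1D (Homo sapiens); on this read-out higher numbers stand for weaker inhibition and lower numbers for stronger inhibition. Compound 2 `c1cc(CNC2CCN(CCCc3c[nH]c4ccc(-n5cnnc5)cc34)CC2)co1` gives 4.5 nM in this assay, and compound 3 `C[C@H](NCC1CCN(CCCc2c[nH]c3ccc(-n4cnnc4)cc23)CC1)c1ccccc1` gives 4.4 nM in this assay. Compound 3 therefore stands second highest of the three numbers: a 1.0-fold lower number from compound 2 to compound 3 (0.01 log units; within the scatter), so compound 2 and compound 3 cannot be told apart, whereas a 2.9-fold higher number from compound 1 to compound 3 (0.47 log units; beyond the scatter), which puts compound 1 clearly at the lower end.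

Compound 4 `CN(Cc1ccco1)C1CCN(CCCc2c[nH]c3ccc(-n4cnnc4)cc23)CC1` has not yet been measured. Relative to compound 3 the change is ((furan-2-yl)methyl)(methyl)amino in place of ((1-phenylethyl)amino)methyl on a saturated ring carbon. Going by the values given here, two measured steps bear on it. The swap of a furan-bearing amine for the phenylethyl-bearing amine gave a 1.0-fold lower number from compound 2 to compound 3 (0.01 log units; within the scatter), a step inside the scatter, so the furan by itself carries no clear penalty. The methyl-bearing amine of compound 1 sits lower than compound 3, as a 2.9-fold higher number from compound 1 to compound 3 (0.47 log units; beyond the scatter) shows, which is a modest step. Compound 4 combines a furan with a methyl on the amine, so a step in this assay of no more than the scatter is expected, if anything toward a slightly lower number.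

Compound 4 is thus estimated at 3 nM in this assay, with a range from 1.2 nM to 7.5 nM. The expected step is a 1.5-fold lower number from compound 3 to compound 4 (0.17 log units; within the scatter).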

Compound 4, half-maximal inhibitory concentration: 9.3 nM
Compound 4: middle estimate off by 3.1-fold (0.49 log units), on the low side; measured number above the stated range.
By their numbers in this assay, from the lowest: compound 1; then compounds 3 and 2 (each within the scatter of the next); then compound 4.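

In this assay, the ((furan-2-yl)methyl)(methyl)amino group on this saturated ring carbon shows that a furan-bearing amine does not always match the other amines at this position: a 2.1-fold higher number from compound 2 to compound 4 (0.32 log units; beyond the scatter) and a 2.1-fold higher number from compound 3 to compound 4 (0.33 log units; beyond the scatter) are both modest but beyond the scatter, whereas compound 2 and compound 3 could not be told apart. Going by these compounds alone, a methyl on the amine nitrogen does not keep the number low on its own, since that methyl is shared by compound 1 and compound 4, and exchanging phenylsulfonyl for (furan-2-yl)methyl on that nitrogen gives a 6.2-fold higher number from compound 1 to compound 4 (0.79 log units; beyond the scatter), the widest step so far. No measurement at hand explains these steps.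

The step from compound 2 to compound 4 changes both the furan attachment and the substitution on the amine nitrogen, so the compounds shown do not separate the two contributions. As far as these compounds go, it also remains open where a benzoyl or methanesulfonyl group on the same methyl-bearing nitrogen would fall relative to compound 1 and compound 4.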